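A few compounds are considered here, and "the series" means these few. Any claim that something is new, unique, unknown or untested is made for them only; others in the source may bear on it.

Compounds measured in an assay on CHO cells for displacement of a labelled ligand from adenosine receptor A3 (Homo sapiens), read by scintillation counting, tested at 10 uM; on this read-out lower numbers stand for less inhibition and higher numbers for more inhibition at the one concentration tested (going by the name of the read-out):
compound 1 `Cc1csc(N)c1C(=O)c1ccc(Cl)cc1` gives 1%;
compound 2 `CC(C)(C)Cc1csc(N)c1C(=O)c1ccc(Cl)cc1` gives 5%.

Compound 2 stands highest of the two numbers, though the step of a number 4 percentage points higher from compound 1 to compound 2 (within the scatter) is within the scatter. Compound 3 `CC(C)(C)Cc1c(-c2cc(F)ccc2F)sc(N)c1C(=O)c1ccc(Cl)cc1` differs from compound 2 by 2,5-difluorophenyl in place of hydrogen on an aromatic carbon. Going by the values given here, no measured step touches that position, and the one step known, a number 4 percentage points higher from compound 1 to compound 2 (within the scatter), concerns a different group, so it gives little guidance. With both measured numbers low, this assay is expected to show only a small rise, a number 10 percentage points higher from compound 2 to compound 3 (within the scatter), for compound 3. Compound 3 is therefore estimated at 15%, between 0% and 45%.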

Compound 3, a percentage reported as inhibition, at one concentration (the size of the read-out at that concentration, not a potency): 1%
Compound 3: middle estimate off by 14 percentage points, on the high side; the range from low to high includes it.
By their numbers in this assay, from the lowest: compounds 1, 3 and 2 (each within the scatter of the next).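

In this assay, going by these compounds alone, putting 2,5-difluorophenyl on the aromatic carbon next to the ring sulfur, a position no earlier step touched, gives a number 4 percentage points lower from compound 2 to compound 3 (within the scatter) and so no reading that stands apart from the scatter. At this concentration, the position takes this aryl group without any detectable gain in inhibition. Nothing available accounts for this result.

On these data alone, whether a carboxylic acid or an amine at this position would read differently in this assay remains open. So does whether this change would behave the same with a group other than neopentyl on the neighbouring ring atom.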